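A few compounds are considered here, and "the series" means these few. Any claim that something is new, unique, unknown or untested is made for them only; others in the source may bear on it.

Measured so far:
- compound 1, `ClCc1ccccc1Cn1cnc2c(Cl)nc(Cl)nc21`: 3470 nM
- compound 2, `ClCc1ccccc1Cn1cnc2c(Cl)ncnc21`: 38000 nM
- compound 3, `ClCc1cccc(Cn2cnc3c(Cl)ncnc32)c1`: 20000 nM

All three were run in a functional assay on 786-0 cells (Homo sapiens) for cytotoxicity, read by sulforhodamine B assay, with a stated time of 48 h; on this read-out higher numbers stand for weaker inhibition of growth and lower numbers for stronger inhibition of growth. Compound 2 and compound 1 share a core and differ in one place: chloro in place of hydrogen on an aromatic carbon. That change gave an 11-fold lower number from compound 2 to compound 1 (1.04 log units; beyond the scatter). Compound 3 and compound 2 are built from the same atoms joined differently; the difference between the two cores is not broken down here. In this assay compound 3 gives 20000 nM, and compound 2 gives 38000 nM; the two values lie within the scatter of each other, so nothing is made of that gap. Compound 1 gives 3470 nM, a gap from compound 3 that is beyond the scatter.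

Compound 4, `ClCc1cccc(Cn2cnc3c(Cl)nc(Cl)nc32)c1`, has not yet been measured in this assay. It stands to compound 3 as compound 1 stands to compound 2: chloro in place of hydrogen on an aromatic carbon. The place is described in the same words in both cases, so this is the same change. Going by the values given here, only one measured instance of it exists, on the other core, and whether it carries over to the core of compound 3 is not known from these data. The expected step is a 10-fold lower number from compound 3 to compound 4 (1.00 log units; beyond the scatter), similar in size to the measured one, because an 11-fold lower number from compound 2 to compound 1 (1.04 log units; beyond the scatter) was found for the same change. For compound 4 the estimate is 2000 nM, with a range from 800 nM to 6000 nM, the width reflecting that the carry-over rests on a single pair.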

Compound 4, concentration for total growth inhibition: 26900 nM
Compound 4: middle estimate off by 13-fold (1.13 log units), on the low side; measured number above the stated range.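

In this assay, chloro in place of hydrogen on an aromatic carbon does not carry over unchanged from one core to the other: the same change on two cores in this assay, an 11-fold lower number (1.04 log units; beyond the scatter) from compound 2 to compound 1 and a 1.3-fold higher number (0.13 log units; within the scatter) from compound 3 to compound 4, 15-fold (1.17 log units) apart, beyond the scatter of two such steps

On the core of compound 3, the step is a 1.3-fold higher number from compound 3 to compound 4 (0.13 log units; within the scatter), so the large step of an 11-fold lower number from compound 2 to compound 1 (1.04 log units; beyond the scatter) cannot be treated as a general property of this change across the series. This does not show why the two cores part ways, and it gives no rule for a further core: the comparison rests on a single pair per core, in one cell line and at one stated time, and the two cores are built from the same atoms joined differently, with that difference not broken down here.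

The compounds shown leave open whether an amine or a methoxy group in the same place, between two ring nitrogen atoms, would also respond differently on the two cores. They also leave open how the chloro change would read if the chloromethyl group shared by all four compounds gave way to a hydroxymethyl group or a longer chain.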